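A few compounds are considered here, and "the series" means these few. Any claim that something is new, unique, unknown or untested is made for them only; others in the source may bear on it.

In a functional assay on ileum for inhibition of histamine H1 receptor (Cavia porcellus) (a lower number here means a stronger inhibitor, a higher number a weaker inhibitor), three compounds have been measured so far:

Compound 1, `CCCN1CCCN(c2nc3ccccc3n2CCOCC)CC1`, gives 8.4 nM.
Compound 2, `CCCCOCCn1c(N2CCCN(C)CC2)nc2ccccc21`, gives 10 nM.
Compound 3, `CCNCCn1c(N2CCN(C)CC2)nc2ccccc21`, gives 290 nM.

Compound 1 thus gives the lowest of the three numbers, but compound 2 lies within the usual scatter of it, so the two cannot be ranked against each other. Only compound 3 stands apart, with a number beyond the scatter and well above that of compound 1. Among the compounds with values here, no pair among the three differs in just one place, so no single step is on hand to lean on, and compound 1 and compound 2, whose numbers sit within the scatter of each other, show no direction.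

The unmeasured compound 4, `CCOCCn1c(N2CCCN(Cc3ccccc3)CC2)nc2ccccc21`, departs from compound 1 by phenyl in place of ethyl on a saturated chain carbon bound to an amine nitrogen in a ring; cut one bond further out, the change reads propyl to benzyl. Within the data shown here, nothing among the measured compounds carries a benzyl on this ring nitrogen, so the size of the step rests on expectation alone. In this assay the step is expected to stay small, if anything toward a somewhat higher number, and not clearly beyond the scatter. The expected step is a 1.8-fold higher number from compound 1 to compound 4 (0.25 log units; within the scatter). Compound 4 is accordingly estimated at 15 nM. Its range is expected to run from 4 nM to 60 nM.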

Compound 4, half-maximal inhibitory concentration: 15 nM
Beside the measured number, compound 4's estimate shows no gap at the digits printed; low and high end bracket the measured number.
By their numbers in this assay, from the lowest: compounds 1, 2 and 4 (each within the scatter of the next); then compound 3.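

In this assay, phenyl in place of ethyl on a saturated chain carbon bound to an amine nitrogen in a ring amounts to a 1.8-fold higher number from compound 1 to compound 4 (0.25 log units; within the scatter), and this is the first step among these compounds that changes one place only. It shows that this position can carry benzyl instead of propyl, and with it a six-membered aromatic ring of carbon only, without a difference that can be told from the usual scatter of the assay. So at this position, for this pair, neither the added ring nor the larger group shows a measurable effect on the number. No measurement at hand speaks to why the number holds at this position.

What the compounds shown leave open is whether the same holds for groups of another kind on this amine nitrogen, such as a carboxylic acid, a hydroxyl-bearing chain or a longer chain ending in phenyl, or for a chlorine or methoxy on the phenyl ring itself. Compound 3 differs from the others in more than one place, so its number still cannot be tied to any single change.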